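The source may hold more compounds than are shown below. What is called first, only, known or untested is meant among the compounds shown, and "the series" means these compounds.

Compound 1 `CCOC(=O)C(=Cc1c(-c2ccccc2)[nH]c2ccccc12)C(=O)OCC`: 3400 nM
Compound 2 `CC(=O)/C(=C\c1c(-c2ccccc2)[nH]c2ccccc12)S(=O)(=O)c1ccccc1`: 1300 nM

In a functional assay on NCI-H522 cells (Homo sapiens) for inhibition, read by sulforhodamine B assay, with a stated time of 48 h (a higher number here means a weaker inhibitor of growth, a lower number a stronger inhibitor of growth), compound 2 stands at the lowest of the two numbers; compound 1 gives a higher number, and that gap lies beyond the scatter. Compound 3 `N#C/C(=C\c1c(-c2ccccc2)[nH]c2ccccc12)S(=O)(=O)c1ccccc1` differs from compound 2 in one place: cyano in place of acetyl on a double-bonded chain carbon bound to a double-bonded chain carbon and a sulfonyl sulfur. Among the measured compounds shown here, no step between measured compounds covers such a change, so in this assay no step beyond the scatter is expected, in either direction. Compound 3 is therefore expected to give about 1200 nM in this assay. Its expected range runs from 400 nM to 3500 nM. The estimate means an expected step of a 1.1-fold lower number from compound 2 to compound 3 (0.03 log units; within the scatter).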

Compound 3, concentration for 50% growth inhibition: 4600 nM
Compound 3: middle estimate off by 3.8-fold (0.58 log units), on the low side, and the stated range ends below it.
By their numbers in this assay, from the lowest: compound 2; then compounds 1 and 3 (each within the scatter of the next).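

In this assay, swapping acetyl for cyano on this double-bonded chain carbon gives a 3.5-fold higher number from compound 2 to compound 3 (0.55 log units; beyond the scatter) and so moves the number beyond the scatter. This position therefore does not tolerate every small group equally, and of these two groups acetyl gives the stronger inhibitor of growth, though this rests on a single pair. No measurement at hand accounts for the step.

From the compounds shown here alone, whether a longer ketone chain, an amide or a carboxylic acid on this carbon would match acetyl or cyano stays open. So does whether the step would carry over to other compounds.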